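A few compounds are considered here, and "the series" means these few. Any claim that something is new, unique, unknown or untested is made for them only; others in the source may bear on it.

Series notes. Going by the values given here, compound 1 `O=C(NCCCCc1ccccc1)n1cc(-c2ccccc2)oc1=O` gives 0.667 h in an ADME assay on microsomes from liver (Mus musculus) for metabolic stability, read by LC-MS, using NADPH, tested at 4.6 uM (on this read-out higher numbers stand for a longer-lived compound and lower numbers for a shorter-lived compound), and is the sole real number in this assay so far. Compound 2 `CCOCCNC(=O)n1cc(-c2ccccc2)oc1=O` returns only a limit, < 0.0834 h. That step, an at least 7.9-fold lower number from compound 1 to compound 2 (0.90 log units; beyond the scatter), rests on (the limit of < 0.0834 h in this assay, at which 1 of the 2 values shown sits). Compound 3 `COc1cc(-c2cn(C(=O)NCCCCc3ccccc3)c(=O)o2)ccc1F` differs from compound 1 by 4-fluoro-3-methoxyphenyl in place of phenyl on an aromatic carbon. Among the compounds with values here, the one measured step alters the chain on the amide-type nitrogen, not the aryl group on the core, so it does not bear on this change directly; no step beyond the scatter is expected, and compound 3 is estimated at 0.6 h (range 0.2 h to 1.5 h), an expected step of a 1.1-fold lower number from compound 1 to compound 3 (0.05 log units; within the scatter).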

Compound 3, half-life: > 1 h
Compound 3 ended at the assay's limit; the forecaster's own chance of this, stated with the estimate: 10%; middle value at least 1.6-fold (0.22 log units) away from the limit.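

Compound 3 gives > 1 h in this assay, which is a limit of the assay and not a number. Going by these compounds alone, this is the first reading at the aromatic carbon next to the ring oxygen: 4-fluoro-3-methoxyphenyl in place of phenyl gives an at least 1.4-fold higher number from compound 1 to compound 3 (0.17 log units; that floor lies within the scatter), so the change shows no sign of a shorter half-life, though the floor alone does not separate the pair. The full size of the step stays unread: the limit of > 1 h in this assay, at which 1 of the 3 values shown sits.

Still open, on these data alone, is whether the fluoro or the methoxy part alone would give the same reading. Also open, as far as these compounds go, is how a pyridine ring at this carbon, or an amine on the chain, would behave.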